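This account rests on a few compounds, and the source may have more. Where it says the series, first, only, none or still open, it means among the compounds named here.

Measured so far in a functional assay on Bel-7402 cells (Homo sapiens) for cytotoxicity, read by MTT assay, with a stated time of 24 h; a lower number here means a stronger inhibitor, a higher number a weaker inhibitor:
- compound 1 `COC(=O)[C@@H](C)NC(=O)Cn1cc(C2=C(c3c[nH]c4ccccc34)C(=O)N(C)C2=O)c2ccccc21` gives 9340 nM
- compound 2 `COC(=O)CCNC(=O)Cn1cc(C2=C(c3c[nH]c4ccccc34)C(=O)N(C)C2=O)c2ccccc21` gives 28400 nM

Among the measured compounds shown here, compound 2 stands at the highest of the two numbers, and its only neighbour is compound 1: a 3.0-fold higher number from compound 1 to compound 2 (0.48 log units; beyond the scatter). That single step is all the data offer, and it concerns exactly the part of the molecule that now changes again.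

Compound 3 `COC(=O)[C@H](NC(=O)Cn1cc(C2=C(c3c[nH]c4ccccc34)C(=O)N(C)C2=O)c2ccccc21)C(C)C` differs from compound 2 in one place: 1-(methoxycarbonyl)-2-methylpropyl in place of 2-(methoxycarbonyl)ethyl on an amide-type nitrogen. The new group restores the 1-(methoxycarbonyl) arrangement of compound 1 and adds a 2-methylpropyl chain in place of the methyl of compound 1. Since the move from a 1-(methoxycarbonyl) to a 2-(methoxycarbonyl) group gave the modest step of a 3.0-fold higher number from compound 1 to compound 2 (0.48 log units; beyond the scatter), reversing that move should give a step of similar size in the other direction, with the extra chain of unknown effect. Compound 3 is therefore expected to show a lower number than compound 2, roughly a 3.2-fold lower number from compound 2 to compound 3 (0.50 log units; beyond the scatter), landing near compound 1. The estimate for compound 3 in this assay is 9000 nM, within a range from 3000 nM to 27000 nM.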

Compound 3, half-maximal inhibitory concentration: 4010 nM
The estimate for compound 3 lay 2.2-fold (0.35 log units) above the measured number; measured number inside the range.
By their numbers in this assay, from the lowest: compound 3; then compound 1; then compound 2.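

In this assay the change from 2-(methoxycarbonyl)ethyl to 1-(methoxycarbonyl)-2-methylpropyl gives a 7.1-fold lower number from compound 2 to compound 3 (0.85 log units; beyond the scatter) and takes compound 3 past compound 1 rather than merely back to its level. The cleaner comparison is isopropyl in place of methyl on a saturated chain carbon bound to an amide-type nitrogen and a carbonyl carbon, which gives a 2.3-fold lower number from compound 1 to compound 3 (0.37 log units; beyond the scatter) and shows that the group on this carbon matters as well as where the ester sits, leaving compound 3 with the lowest number of the three, its steps to both others beyond the scatter. Nothing measured here explains why the isopropyl compound gives the lower number.

On these data alone, with only a methyl and an isopropyl to compare, it remains open whether the number keeps falling with a larger group on this carbon, such as a benzyl or a longer chain, or whether a bare hydrogen there would reverse the trend. As far as these compounds go, it is also open how much the methyl ester itself contributes, which a carboxylic acid or a primary amide in its place would test.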